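Repositioning chlorine on the aryl group of compound 3

The compounds below may be only part of what the source reports. "The series", "measured", "known", "first", "only" and "open" are said of these compounds alone.

Compound 3 `Nc1ncnn2c([C@@H]3O[C@H](CO)[C@@H](O)[C@H]3O)cc(-c3ccc(Cl)cc3)c12` carries a 4-chlorophenyl group on the shared core; its two companions keep alkynyl groups there. In a functional assay on CAPAN-1 cells (Homo sapiens) for antiproliferative activity, with a stated time of 72 h (a higher number here means a weaker inhibitor, a lower number a stronger inhibitor), compound 3 gives 56700 nM, the highest of the three numbers. Compound 1 `CCCCC#Cc1cc([C@@H]2O[C@H](CO)[C@@H](O)[C@H]2O)n2ncnc(N)c12` gives 1000 nM, and compound 2 `Nc1ncnn2c([C@@H]3O[C@H](CO)[C@@H](O)[C@H]3O)cc(C#CC3CC3)c12` gives 20 nM. The step of a 57-fold higher number from compound 1 to compound 3 (1.75 log units; beyond the scatter) and the step of a 2800-fold higher number from compound 2 to compound 3 (3.45 log units; beyond the scatter) both show that placing the 4-chlorophenyl group on this aromatic carbon costs a great deal against either alkyne, while a 50-fold lower number from compound 1 to compound 2 (1.70 log units; beyond the scatter) shows how sensitive the alkyne side is to its own substituent.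

Compound 4 `Nc1ncnn2c([C@@H]3O[C@H](CO)[C@@H](O)[C@H]3O)cc(-c3ccccc3Cl)c12` differs from compound 3 only in 2-chlorophenyl in place of 4-chlorophenyl on an aromatic carbon. Going by the values given here, no measured step moves a chlorine around a phenyl ring, so none bears directly on this change; the measured steps only say that an aryl group at this carbon sits far from the alkynes. Compound 4 is therefore expected to remain an aryl compound of roughly the same standing as compound 3, with a 1.4-fold lower number from compound 3 to compound 4 (0.15 log units; within the scatter) expected to stay within the scatter, the direction being uncertain. The estimate for compound 4 in this assay is 40000 nM, with a range from 10000 nM to 150000 nM.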

Compound 4, half-maximal inhibitory concentration: 54900 nM
Compound 4: the middle estimate sits 1.4-fold (0.14 log units) below what was measured; the range from low to high includes it.
By their numbers in this assay, from the lowest: compound 2; then compound 1; then compounds 4 and 3 (each within the scatter of the next).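

Moving the chlorine leaves the number in this assay unchanged within the scatter (a 1.0-fold lower number from compound 3 to compound 4 (0.01 log units; within the scatter)), so 2-chlorophenyl and 4-chlorophenyl cannot be told apart on this aromatic carbon of the five-membered ring. The gulf between aryl and alkyne therefore does not depend on which of these two chlorophenyl groups is present: it remains large against the cyclopropyl alkyne (a 2700-fold higher number from compound 2 to compound 4 (3.44 log units; beyond the scatter)) and against the hexynyl group (a 55-fold higher number from compound 1 to compound 4 (1.74 log units; beyond the scatter)). Nothing available explains why the place of the chlorine makes no difference here, or why both chlorophenyl compounds stand so far from the alkynes.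

The compounds shown leave open whether any aryl group at this carbon can close that gap, since they include only these two chlorophenyl groups and no plain phenyl, pyridine ring or phenyl bearing an amine or a carboxylic acid in place of the chlorine. They also leave open whether a group with a triple bond is what matters, as no saturated chain such as hexyl or ethyl cyclopropane appears at this carbon for comparison.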